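Swapping one side chain on compound 1

The compounds below may be only part of what the source reports. "The series", "measured", "known", "first", "only" and "open" are said of these compounds alone.

Compound 1 `C/C=C/COc1noc2c1CNCC2`: 7.7
Compound 2 `CCOc1noc2c1CN(C)CC2`: 6.6
Compound 3 `CCN1CCc2onc(OC)c2C1`: 7

In a physicochemical assay for acid dissociation, compound 1 gives 7.7, the highest of the three numbers, and compound 2 and compound 3 both lie lower by more than the scatter. Compound 4 `CC(C)COc1noc2c1CNCC2` has not yet been measured. It differs from compound 1 by one change: isopropyl in place of prop-1-en-1-yl on a saturated chain carbon bound to an oxygen on an aromatic ring. Among the measured compounds shown here, no measured pair shows this change, which leaves compound 1 at 7.7 as the starting point. In this assay, the expected move, a number 0.10 log units higher from compound 1 to compound 4 (within the scatter), stays within the scatter. For compound 4 the estimated value is 7.8, with an expected range of 7.4 to 8.2.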

Compound 4, acid dissociation constant: 7.7
Estimate against measurement, compound 4: 0.10 log units above, within the range that was stated.
By their numbers in this assay, from the lowest: compound 2; then compound 3; then compounds 1 and 4 (each within the scatter of the next).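

In this assay, isopropyl in place of prop-1-en-1-yl on a saturated chain carbon bound to an oxygen on an aromatic ring gives no change at the digits printed from compound 1 to compound 4 (within the scatter) and forms the only single-change pair shown at this position. Here, the double bond outside aromatic rings can go, and the three carbons can be rearranged into isopropyl, without a shift beyond the scatter. Nothing available explains this result. Going by these compounds, whether an amine, a carboxylic acid or a longer chain such as hexyl in this place would leave the number equally unmoved stays open.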